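This account rests on a few compounds, and the source may have more. Where it says the series, first, only, none or still open, it means among the compounds named here.

Series notes. The shared core of compound 1 `C=C(C)[C@@H]1CC=C(Cn2cc(COc3ccccc3C3NC(=O)NC(C)=C3C(=O)OCC)nn2)CC1` carries an ethoxycarbonyl group; in a functional assay on PC-3 cells (Homo sapiens) for inhibition, read by sulforhodamine B assay, with a stated time of 48 h (on this read-out lower numbers stand for stronger inhibition of growth and higher numbers for weaker inhibition of growth), compound 1 sits at the limit of the method, (the limit of > 100000 nM in this assay, at which 1 of the 3 values shown sits), and gives > 100000 nM, so no number stands for it. Compound 2 `C=C(C)[C@@H]1CC=C(Cn2cc(COc3ccc(C4NC(=O)NC(C)=C4C(=O)OCC)cc3OC)nn2)CC1` gives 54400 nM in this assay. For the measured compounds named here, compound 3 `C=C(C)[C@@H]1CC=C(Cn2cc(COc3cccc(C4NC(=O)NC(C)=C4C(C)=O)c3)nn2)CC1`, the one acetyl compound with a number, gives 49800 nM in this assay. Compound 4 `C=C(C)[C@@H]1CC=C(Cn2cc(COc3ccccc3C3NC(=O)NC(C)=C3C(C)=O)nn2)CC1` differs from compound 1 in one place: methyl in place of ethoxy on a carbonyl carbon. Going by the values given here, no measured pair with this exact change exists in the set, so the size of the step is uncertain. Given that compound 3 gives 49800 nM, compound 4 is expected to move toward a readable value, an estimated step of an at least 1.3-fold lower number from compound 1 to compound 4 (0.12 log units; that floor lies within the scatter). Compound 4 is therefore estimated at 75000 nM, range 30000 nM to 200000 nM, with a real chance that only a limit is reported again.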

Compound 4, concentration for total growth inhibition: 62000 nM
The estimate for compound 4 lay 1.2-fold (0.08 log units) above the measured number; the measured number falls inside the stated range.
By their numbers in this assay, from the lowest: compounds 3, 2 and 4 (each within the scatter of the next). At a limit, above all of these: compound 1.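

Methyl in place of ethoxy on a carbonyl carbon gives the first one-place comparison in the series, with a readable number replacing a limit in this assay: an at least 1.6-fold lower number from compound 1 to compound 4 (0.20 log units; that floor lies within the scatter). Compound 1 remains a limit, not a number: the limit of > 100000 nM in this assay, at which 1 of the 4 values shown sits. Going by these compounds, only a floor for the step can be read, and its true size stays unknown.

The compounds shown leave open whether this step carries over to the other compounds of the series. They also leave open how a carboxylic acid, an amine-derived amide or a longer chain on the same carbonyl carbon would read.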